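From 3-bromophenyl to 2-methoxyphenyl in a cell toxicity test

The compounds below may be only part of what the source reports. "The series", "measured", "known", "first", "only" and "open" are said of these compounds alone.

- Compound 1 `Cn1c(-c2ccccc2)cnc1NC(=O)c1ccc(F)cc1` gives > 100000 nM
- Compound 2 `Cn1c(-c2cccc(Br)c2)cnc1NC(=O)c1ccc(F)cc1` gives > 50000 nM

In a toxicity assay on THP-1 cells (Homo sapiens) for inhibition (on this read-out lower numbers stand for higher toxicity in this test and higher numbers for lower toxicity in this test), compound 2 gives > 50000 nM as its reading, a limit of the assay and not a number. Compound 1 gives > 100000 nM as its reading, also a limit. For the measured compounds named here, the one measured step is a step that the two limits leave unreadable from compound 1 to compound 2 and so offers no size to carry over. Compound 3 `COc1ccccc1-c1cnc(NC(=O)c2ccc(F)cc2)n1C` carries 2-methoxyphenyl in place of 3-bromophenyl on an aromatic carbon. With compound 2 at > 50000 nM as a limit, no step beyond the usual scatter is expected in this assay for compound 3. Put as a step, the expectation is (a step that the limit leaves unreadable from compound 2 to compound 3). For compound 3 the estimated value is 70000 nM within an expected range of 30000 nM to 150000 nM and a further limit is the likeliest kind of result.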

Compound 3, half-maximal cytotoxic concentration: > 100000 nM
Compound 3: no number, only a limit; the forecaster's own chance of this, stated with the estimate: 85%; middle value at least 1.4-fold (0.15 log units) from the limit.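

For the compounds shown here, no step between compound 1, compound 2 and compound 3 can be read in this assay: all three readings are limits, not numbers. The compounds shown leave open what concentration, if any, would be toxic to these cells, and whether 3-bromophenyl or 2-methoxyphenyl changes it.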